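The compounds below may be only part of what the source reports. "The series", "measured", "known", "first", "only" and "open" are said of these compounds alone.

In a functional assay on RXF 393 cells (Homo sapiens) for inhibition, read by sulforhodamine B assay, with a stated time of 48 h (on this read-out lower numbers stand for stronger inhibition of growth and higher numbers for weaker inhibition of growth), compound 1 `Nc1cc(N)c2nc(-c3ccccc3)c(Oc3ccc(Cl)c(Cl)c3)nc2c1` gives 58900 nM, the highest of the two numbers in hand; compound 2 `COc1cc(CNc2nc3cc(N)cc(N)c3nc2-c2ccccc2)cc(OC)c1OC` gives 20000 nM, a number beyond the usual scatter away from that of compound 1. Compound 3 `Nc1cc(N)c2nc(-c3ccccc3)c(Sc3ccc(F)cc3)nc2c1` carries (4-fluorophenyl)sulfanyl in place of 3,4-dichlorophenoxy on an aromatic carbon. Among the measured compounds shown here, no pair of measured compounds shows what such a change does here, so compound 3 is expected to stay near compound 1, with a step from compound 1 to compound 3 of a 1.2-fold lower number from compound 1 to compound 3 (0.07 log units; within the scatter) that need not go beyond the scatter in either direction. For compound 3 the estimated value is 50000 nM, within a range from 15000 nM to 150000 nM.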

Compound 3, concentration for total growth inhibition: < 100000 nM
Compound 3 was reported as a limit; the forecaster's own chance of this, stated with the estimate: 10%; the middle value lies beyond the limit too.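

In this assay, among the compounds shown here, compound 3 is given only as the limit < 100000 nM and no step from compound 1 to compound 3 can be read. Going by these compounds, it remains open whether (4-fluorophenyl)sulfanyl in place of 3,4-dichlorophenoxy moves the number beyond the scatter in either direction.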